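Fluoro in Place of Amino on a Shared Core

This account rests on a few compounds, and the source may have more. Where it says the series, first, only, none or still open, it means among the compounds named here.

Compound 1 `CC(=O)OC(C)n1cnc2c(S)nc(N)nc21` and compound 3 `CC(=O)OC(C)n1cnc2c(S)nc(F)nc21` differ in one place: fluoro in place of amino on an aromatic carbon. In a functional assay on WI-38 cells (Homo sapiens) for inhibition (a higher number here means a weaker inhibitor, a lower number a stronger inhibitor), compound 1 gives 400 nM. For compound 3 this assay reports only a limit, > 500000 nM. The step is an at least 1200-fold higher number from compound 1 to compound 3 (3.09 log units; beyond the scatter). Compound 2 `CC(=O)OCCOn1cnc2c(S)nc(N)nc21` carries another side chain; the difference between the two cores is not broken down here. For compound 2 this assay again reports only a limit, > 500000 nM. Compound 4 `CC(=O)OCCOn1cnc2c(S)nc(F)nc21` has not yet been measured and differs from compound 2 by the same kind of change: fluoro in place of amino on an aromatic carbon. The expectation for compound 4 rests on an at least 1200-fold higher number from compound 1 to compound 3 (3.09 log units; beyond the scatter) and on (the limit of > 500000 nM in this assay, at which 2 of the 3 values shown sit). Compound 4 is therefore expected to give about 1000000 nM, most likely reported only as a limit. The estimated step that the limit leaves unreadable from compound 2 to compound 4 is expected to be indistinct, since both ends would lie at the limit.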

Compound 4, half-maximal inhibitory concentration: > 500000 nM
Compound 4 ended at the assay's limit; the forecaster's own chance of this, stated with the estimate: 95%; the middle value does not contradict the limit.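

No step can be read from compound 2 to compound 4 in this assay, because both end at a limit: the limit of > 500000 nM in this assay, at which 3 of the 4 values shown sit.

The compounds shown leave open whether fluoro in place of amino changes anything when it is made on compound 2.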